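A few compounds are considered here, and "the series" means these few. Any claim that something is new, unique, unknown or untested is made for them only; others in the source may bear on it.

Compound 1, `CC1OC(=O)c2cc(C#N)c(N3CCC(C(=O)NS(=O)(=O)Cc4ccccc4)CC3)nc21`, is inactive as far as can be told: in a functional assay (Platelet, plasma) for inhibition, with Homo sapiens as the target (a higher number here means a weaker inhibitor, a lower number a stronger inhibitor), compound 1 gives only a limit, > 300000 nM. Compound 2, `N#Cc1cc2c(nc1N1CCC(C(=O)NS(=O)(=O)C(F)(F)c3ccccc3)CC1)COC2=O`, differs from it only in the group on the sulfonyl sulfur, and for compound 2 the entry in this assay reads "not determined" (no result reported), so no number stands for it. Compound 3, `N#Cc1cc2c(nc1N1CCC(C(=O)NS(=O)(=O)Cc3cccc(F)c3)CC1)COC2=O`, carries 3-fluorobenzyl in place of difluoro(phenyl)methyl on a sulfonyl sulfur. Within the data shown here, with no measured step to go by, the only fixed point is the limit of > 300000 nM in this assay, at which 1 of the 2 values shown sits, and a weak result is expected for compound 3 too. Compound 3 is estimated at 300000 nM, between 50000 nM and 1000000 nM, in this assay.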

Compound 3, half-maximal inhibitory concentration: 70500 nM
Estimate against measurement, compound 3: 4.3-fold (0.63 log units) above, and the stated range covers the measured number.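

No step can be read for compound 3, as compound 2 has no number in this assay to compare with. The compounds shown leave open how the group on the sulfonyl sulfur affects inhibition.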